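A few compounds are considered here, and "the series" means these few. Any claim that something is new, unique, unknown or untested is made for them only; others in the source may bear on it.

Measured in a functional assay on A549 cells (Homo sapiens) for cytotoxicity, read by MTT assay, with a stated time of 72 h; on this read-out lower numbers stand for stronger inhibition and higher numbers for weaker inhibition:
- Compound 1 `O=S(=O)(c1ccc(Br)cc1)c1nc2ccccc2nc1N1CCCC1`: > 50000 nM, a limit, not a number
- Compound 2 `O=S(=O)(c1ccc(Br)cc1)c1nc2ccccc2nc1N1CCc2ccccc2C1`: > 50000 nM, a limit, not a number
- Compound 3 `Cc1ccc(S(=O)(=O)c2nc3ccccc3nc2N2CCCC(O)C2)cc1`: 1350 nM

For the measured compounds named here, compound 3, at 1350 nM, is the only compound with a real number. The rest is the limit of > 50000 nM in this assay, at which 2 of the 3 values shown sit.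

Compound 4 `O=S(=O)(c1ccc(Br)cc1)c1nc2ccccc2nc1N1CCCC(O)C1` changes one spot of compound 3: bromo in place of methyl on an aromatic carbon. Going by the values given here, the only measured step, a step that the two limits leave unreadable from compound 1 to compound 2, concerns another group, so no measured step sizes this swap.

Like compound 1, compound 2 carries 4-bromophenyl, with a different group elsewhere, and gives > 50000 nM, a limit, so a modest weakening in this assay is the likelier direction.

The expected step is a 1.5-fold higher number from compound 3 to compound 4 (0.17 log units; within the scatter).

For compound 4 the estimated value is 2000 nM, expected within 500 nM to 12000 nM.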

Compound 4, half-maximal inhibitory concentration: 2100 nM
Estimate against measurement, compound 4: 1.1-fold (0.02 log units) below, within the range that was stated.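

In this assay, the swap on this aromatic carbon makes no readable difference, with a 1.6-fold higher number from compound 3 to compound 4 (0.19 log units; within the scatter). With 4-bromophenyl held constant, replacing the other group gives far larger steps, with an at least 23-fold lower number from compound 1 to compound 4 (1.37 log units; beyond the scatter) and an at least 23-fold lower number from compound 2 to compound 4 (1.37 log units; beyond the scatter). Those two steps start from limits, not numbers, so they give only a minimum size: the limit of > 50000 nM in this assay, at which 2 of the 4 values shown sit.

From the compounds shown here alone, whether an amine or a carboxylic acid in place of bromo would also leave the number unchanged remains open. So does whether plain piperidin-1-yl, lacking the hydroxyl, would match 3-hydroxypiperidin-1-yl.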